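A few compounds are considered here, and "the series" means these few. Any claim that something is new, unique, unknown or untested is made for them only; others in the source may bear on it.

Going by the values given here, in a functional assay on SNU-638 cells (Homo sapiens) for antiproliferative activity, read by sulforhodamine B assay, with a stated time of 72 h (on this read-out higher numbers stand for weaker inhibition and lower numbers for stronger inhibition), only two compounds have numbers so far. Compound 1 (`CCCCS(=O)(=O)Nc1cc(-c2ccc3ncnc(NCCN(C)C)c3c2)cnc1OC`) gives 480 nM in this read-out. Compound 2 (`COc1ncc(-c2ccc3ncnc(NCCCN(C)C)c3c2)cc1NS(=O)(=O)c1ccc(F)cc1F`) gives 1260 nM and so holds the higher of the two numbers, which makes it the weaker inhibitor of the pair, with a gap to compound 1 that lies beyond the usual scatter.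

Compound 3 (`CCCCS(=O)(=O)Nc1cc(-c2ccc3ncnc(NCCCN(C)C)c3c2)cnc1OC`) has not yet been measured. It differs from compound 2 by having butyl in place of 2,4-difluorophenyl on a sulfonyl sulfur.

Among the compounds with values here, no measured pair isolates this change, so this assay offers no direct precedent for the size of the step. The only other reference point is compound 1 (480 nM), which pulls the expectation toward the lower side of compound 2 but is weak evidence on its own. The estimated step of a 1.9-fold lower number from compound 2 to compound 3 (0.29 log units; within the scatter) is a modest move toward stronger inhibition and is not expected to lie clearly beyond the scatter. For compound 3 the expected value is 650 nM, with an estimated range from 220 nM to 1800 nM.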

Compound 3, half-maximal inhibitory concentration: 1260 nM
Compound 3: middle estimate off by 1.9-fold (0.29 log units), on the low side; the measured number falls inside the stated range.
By their numbers in this assay, from the lowest: compound 1; then compounds 2 and 3 (each within the scatter of the next).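

In this assay, butyl in place of 2,4-difluorophenyl on a sulfonyl sulfur gives no change at the digits printed from compound 2 to compound 3 (within the scatter), so for this pair, which carries (dimethylamino)methyl on the chain, the loss of the aromatic ring at the sulfonyl sulfur leaves the read-out unmoved. Going by these compounds alone, with butylsulfonyl held constant, (dimethylamino)methyl in place of dimethylamino on a saturated chain carbon, two bonds along the chain from a nitrogen on an aromatic ring, gives a 2.6-fold higher number from compound 1 to compound 3 (0.42 log units; beyond the scatter), which is the only single-place step beyond the scatter in this small set and places the sensitivity seen so far at the chain rather than at the sulfonyl group. No measurement at hand accounts for either outcome.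

The compounds shown leave open whether the sulfonyl position stays this tolerant with dimethylamino on the chain, where 2,4-difluorophenyl has no direct partner for compound 1, and with other groups there, such as methyl or a carboxylic acid-bearing chain. They also leave open how the chain responds when its terminal dimethylamino is replaced by a morpholine or a piperidine.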